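The compounds below may be only part of what the source reports. "The series", "measured", "known", "first", "only" and "open" are said of these compounds alone.

Compound 1 `CCCOc1ccccc1-c1nc2ccccc2[nH]1` — in a functional assay on the whole organism (ileum) with Rattus norvegicus as the target (a higher number here means a larger maximal response, a lower number a smaller maximal response), compound 1 gives 80%.
Compound 2 `c1ccc(COc2ccccc2-c2nc3ccccc3[nH]2)cc1` — in this assay compound 2 gives 51.4%.
Compound 3 `Clc1ccc(COc2ccccc2-c2nc3ccccc3[nH]2)cc1` — in this assay compound 3 gives 38.2%.

Compound 3 has the lowest of the three numbers. Its nearest neighbour is compound 2, separated by the step of a number 13.2 percentage points lower from compound 2 to compound 3 (beyond the scatter); compound 1 stands furthest away, separated by a number 41.8 percentage points lower from compound 1 to compound 3 (beyond the scatter). Between the two benzyl ethers and the propyl ether the gap is also set by a number 28.6 percentage points lower from compound 1 to compound 2 (beyond the scatter), so both benzyl groups sit well under the propyl group.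

Compound 4 `Cc1ccc(COc2ccccc2-c2nc3ccccc3[nH]2)cc1` differs from compound 3 by methyl in place of chloro on an aromatic carbon. Within the data shown here, the only measured step at this position is a number 13.2 percentage points lower from compound 2 to compound 3 (beyond the scatter), in which chloro in place of hydrogen lowered the largest response by a modest amount. Among the measured compounds shown here, no measured pair shows methyl in place of chloro, so the new step rests on this single comparison. Compound 4 is expected to land between compound 2 and compound 3, giving a small upward step a number 5.8 percentage points higher from compound 3 to compound 4 (within the scatter) that may not exceed the scatter. For compound 4 the estimate in this assay is 44%, with a range from 30% to 58%.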

Compound 4, largest response reached (Emax), in percent of the reference or control that the assay uses: 47.7%
Beside the measured number, compound 4's estimate is 3.7 percentage points below it, and the stated range covers the measured number.
By their numbers in this assay, from the lowest: compounds 3, 4 and 2 (each within the scatter of the next, the first and the last beyond it); then compound 1.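

In this assay the methyl group cannot be told apart from either neighbour at this position: a number 9.5 percentage points higher from compound 3 to compound 4 (within the scatter) is read as no separation from the chloro compound, and a number 3.7 percentage points lower from compound 2 to compound 4 (within the scatter) is read as no separation from the unsubstituted benzyl ether. Chloro in place of hydrogen remains the only change on this aromatic carbon with a step beyond the scatter, so a substituent here does not by itself separate a compound from the unsubstituted benzyl ether. Against the propyl ether the 4-methylbenzyl group still shows a number 32.3 percentage points lower from compound 1 to compound 4 (beyond the scatter) and so joins the 4-chlorobenzyl and benzyl ethers well under compound 1 in this read-out, with nothing in hand that bears on why these values fall as they do.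

Open, as far as these compounds go, is whether a methoxy group, an amine or a carboxylic acid at this same carbon would give a step beyond the scatter from the unsubstituted benzyl ether. Also open, from the compounds shown here alone, is how the largest response runs along a longer chain than propyl on the oxygen, or with the substituent moved elsewhere on the benzyl ring.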